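This account rests on a few compounds, and the source may have more. Where it says the series, first, only, none or still open, it means among the compounds named here.

In a functional assay on HeLa cells (Homo sapiens) for antiproliferative activity, read by MTT assay, with a stated time of 72 h (on this read-out higher numbers stand for weaker inhibition and lower numbers for stronger inhibition), compound 3 (`COc1cc(-c2ncnn2-c2ccccc2)cc(OC)c1OC`) gives > 10000 nM as a limit and not a number. Compound 1 (`COc1cc(-c2ncnn2-c2cccc(F)c2)cc(OC)c1OC`) gives > 10000 nM as a limit too. Compound 2 (`COc1cc(-c2ncnn2-c2cccc(N)c2)cc(OC)c1OC`) gives > 10000 nM as a limit too. Compound 3 therefore stands with the others at the limit of > 10000 nM in this assay, at which 3 of the 3 values shown sit, and no number places it. Compound 4 (`COc1cc(-c2ncnn2-c2cccc([N+](=O)[O-])c2)cc(OC)c1OC`) differs from compound 3 by one change (nitro in place of hydrogen on an aromatic carbon) with nitro in place of hydrogen on an aromatic carbon. Bearing on it are a step that the two limits leave unreadable from compound 1 to compound 2 and a step that the two limits leave unreadable from compound 1 to compound 3 and a step that the two limits leave unreadable from compound 2 to compound 3 so no size carries over. No step beyond the scatter is therefore expected in this assay in either direction. The expected step is a step that the limit leaves unreadable from compound 3 to compound 4 and a further limit is likely. For compound 4 the estimate is 15000 nM with 6000 nM and 40000 nM as the expected ends of the range.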

Compound 4, half-maximal inhibitory concentration: > 10000 nM
Compound 4 was reported as a limit (the forecaster's own chance of this, stated with the estimate: 85%); the middle value is on the limit's open side.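

In this assay, within the data shown here, compound 4 gives > 10000 nM, a limit and not a number, so no step from compound 1, compound 2 or compound 3 to compound 4 can be read. The compounds shown leave open whether any group at this place on the aromatic ring gives a number and not a limit: the limit of > 10000 nM in this assay, at which 4 of the 4 values shown sit.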